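This account rests on a few compounds, and the source may have more. Where it says the series, first, only, none or still open, it means among the compounds named here.

Measured so far: compound 1 `Cc1cc(=O)oc2cc(OCc3nc(N)nc(Nc4ccc(Cl)cc4)n3)ccc12` gives 32500 nM in an assay on COS-7 cells for agonist activity at Free fatty acid receptor 1 (Homo sapiens), read by scintillation counting and inositol phosphate accumulation, with a stated time of 90 min; on this read-out lower numbers stand for an effect already at smaller amounts and higher numbers for an effect only at larger amounts of compound; compound 2 `Cc1ccc(Nc2nc(N)nc(COc3ccc4c(C)cc(=O)oc4c3)n2)cc1` gives 1790 nM; compound 3 `Cc1ccc(Nc2nc(N)nc(COc3cc(Cl)cc(N4CCCC4=O)c3)n2)cc1Cl` gives 160 nM.

Compound 1 and compound 2 differ in one place, (methyl in place of chloro on an aromatic carbon), and this gave an 18-fold lower number from compound 1 to compound 2 (1.26 log units; beyond the scatter). Compound 3 has a different core from compound 1; the difference between the two cores is not broken down here. Compound 3 stands lowest of the three numbers, with compound 2 nearest and compound 1 furthest.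

Compound 4 `Cc1cc(OCc2nc(N)nc(Nc3ccc(C)c(Cl)c3)n2)cc(N2CCCC2=O)c1` has not yet been measured in this assay. It differs from compound 3 by methyl in place of chloro on an aromatic carbon. This is the same kind of change as that from compound 1 to compound 2, but it sits in a different place: in compound 2 the methyl stands para to a large group, whereas in compound 4 it stands meta to a 2-oxopyrrolidin-1-yl group and meta to a large group. Because the earlier step was an 18-fold lower number from compound 1 to compound 2 (1.26 log units; beyond the scatter), a lower number for compound 4 is expected, but a smaller step, estimated as a 1.8-fold lower number from compound 3 to compound 4 (0.25 log units; within the scatter), since the place is not the same. Compound 4 is expected to give about 90 nM, between 25 nM and 350 nM.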

Compound 4, half-maximal effective concentration: 20 nM
The estimate for compound 4 lay 4.5-fold (0.65 log units) above the measured number; the measured number lies below the stated range.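

In this assay, methyl in place of chloro on an aromatic carbon gave an 8.0-fold lower number from compound 3 to compound 4 (0.90 log units; beyond the scatter), so the change lowered the number on a second core as well as on the first. The two steps point the same way and do not differ in size beyond what repeated measurement would produce: the same change on two cores in this assay, an 18-fold lower number (1.26 log units; beyond the scatter) from compound 1 to compound 2 and an 8.0-fold lower number (0.90 log units; beyond the scatter) from compound 3 to compound 4, 2.3-fold (0.36 log units) apart, within the scatter of two such steps. This shows that across these two pairs the change carried over from one core to the other, even though it sits at a different place in each; it does not show that it would carry over to any further core, and two pairs say nothing about why the number falls.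

The compounds shown leave open whether a methoxy group or an amine on the same aromatic carbon would lower the number as methyl does. They also leave open whether the step would hold with a carboxylic acid in place of the 2-oxopyrrolidin-1-yl group.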